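The source may report more compounds than this note shows. Statements on the series, on what has been measured and on what is new or still open speak of the compounds shown alone.

In a functional assay on CEM-DNR-bulk cells (Homo sapiens), read by MTT assay, with a stated time of 72 h (a higher number here means a weaker inhibitor, a lower number a stronger inhibitor), compound 3 (`CNc1ncnc2c1c(-c1ccoc1)cn2[C@@H]1O[C@H](CO)[C@@H](O)[C@H]1O`) gives > 20000 nM, which is a limit of the assay and not a number. Compound 2 (`CNc1ncnc2c1c(-c1ccco1)cn2[C@@H]1O[C@H](CO)[C@@H](O)[C@H]1O`) also gives a limit, > 20000 nM. Compound 1 (`CSc1ncnc2c1c(-c1cccs1)cn2[C@@H]1O[C@H](CO)[C@@H](O)[C@H]1O`), which carries a thiophen-2-yl, gives a limit as well, > 20000 nM. Every result so far is therefore the same: the limit of > 20000 nM in this assay, at which 3 of the 3 values shown sit.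

Compound 4 (`CNc1ncnc2c1c(-c1cccs1)cn2[C@@H]1O[C@H](CO)[C@@H](O)[C@H]1O`) has thiophen-2-yl in place of furan-3-yl on an aromatic carbon, (thiophen-2-yl in place of furan-3-yl on an aromatic carbon). For the measured compounds named here, the one measured change of this kind is furan-3-yl in place of furan-2-yl, a step that the two limits leave unreadable from compound 2 to compound 3. Going by the values given here, no measured step of readable size exists, so nothing here points to a change in either direction in this assay, and another limit is the likeliest result. The expected change is a number no higher from compound 3 to compound 4 (the limit leaves the size open), which amounts to no clear step. For compound 4 the estimate is 20000 nM, with an expected range from 8000 nM to 30000 nM.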

Compound 4, half-maximal inhibitory concentration: > 20000 nM
Compound 4 gave a limit, no number; the forecaster's own chance of this, stated with the estimate: 80%; the middle value sits exactly at the limit.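

Compound 4 also gives a limit and not a number, so its steps from compound 1, compound 2 and compound 3 cannot be read: the limit of > 20000 nM in this assay, at which 4 of the 4 values shown sit.

The compounds shown leave open how thiophen-2-yl, furan-2-yl and furan-3-yl compare in this assay, and whether any change to them would give a measurable number.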